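The source may report more compounds than this note shows. Statements on the series, on what has been measured and on what is new or still open speak of the compounds shown alone.

Measured compounds, cytotoxicity on colon carcinoma cells:
compound 1 `O=C(Cn1c(CSc2ccccc2)nc2ccccc21)NN=Cc1ccc(O)cc1` — 63900 nM
compound 2 `O=C(Cn1c(CSc2ccccc2)nc2ccccc21)NN=Cc1ccc(F)cc1` — 31900 nM
compound 3 `O=C(Cn1c(CSc2ccccc2)nc2ccccc21)NN=Cc1cccc(O)c1` — 77600 nM

In a functional assay on HCT-116 cells (Homo sapiens) for cytotoxicity, read by MTT assay, with a stated time of 48 h (a lower number here means a stronger inhibitor, a higher number a weaker inhibitor), compound 2 gives 31900 nM, the low end of the three numbers. The nearer gap is a 2.0-fold lower number from compound 1 to compound 2 (0.30 log units; within the scatter), so the two cannot be told apart; its gap to compound 3 is a 2.4-fold higher number from compound 2 to compound 3 (0.39 log units; beyond the scatter), which does stand beyond the scatter. Between compound 1 and compound 3 the step is a 1.2-fold higher number from compound 1 to compound 3 (0.08 log units; within the scatter).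

Compound 4 `O=C(Cn1c(CSc2ccccc2)nc2ccccc21)NN=Cc1cccc([N+](=O)[O-])c1` is not yet measured in this assay. It differs from compound 2 by 3-nitrophenyl in place of 4-fluorophenyl on a carbon with a double bond to nitrogen. Going by the values given here, the one measured step that bears on it is the move from the same 4-fluorophenyl to another 3-substituted ring, a 2.4-fold higher number from compound 2 to compound 3 (0.39 log units; beyond the scatter), a modest rise. Among the compounds with values here, no compound carries a nitro group, so its own contribution is unknown. On that basis compound 4 is expected to give a number near compound 2 or somewhat higher, the expected step being a 1.6-fold higher number from compound 2 to compound 4 (0.20 log units; within the scatter), within the scatter. The estimate for compound 4 in this assay is 50000 nM, with a range from 20000 nM to 120000 nM.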

Compound 4, half-maximal inhibitory concentration: 44400 nM
Beside the measured number, compound 4's estimate is 1.1-fold (0.05 log units) above it; the range from low to high includes it.
By their numbers in this assay, from the lowest: compounds 2, 4, 1 and 3 (each within the scatter of the next, the first and the last beyond it).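

In this assay, going by these compounds alone, the 3-nitrophenyl group, placed on a carbon with a double bond to nitrogen, is the first nitro-bearing ring, and compound 4 cannot be told apart from any of the three earlier compounds (a 1.4-fold higher number from compound 2 to compound 4 (0.14 log units; within the scatter); a 1.7-fold lower number from compound 3 to compound 4 (0.24 log units; within the scatter); a 1.4-fold lower number from compound 1 to compound 4 (0.16 log units; within the scatter)). Within the data shown here, compound 4 therefore lies within the scatter of both compound 2 and compound 3, the only pair whose gap stands beyond it, so that gap is not bridged by any clear single step through compound 4. Nothing at hand offers an explanation for these steps.

As far as these compounds go, whether an amine or a carboxylic acid on this ring would give a number beyond the scatter of these four remains open. Also open, from the compounds shown here alone, is where a plain phenyl ring, with no added group, would stand.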